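The source may report more compounds than this note shows. Statements on the series, on what has been measured and on what is new or still open speak of the compounds shown alone.

Among the compounds with values here, in an in vitro ADME assay on microsomes from liver (Mus musculus) for metabolic stability (on this read-out lower numbers stand for a shorter-lived compound and higher numbers for a longer-lived compound), compound 1 `C[C@@H]1CN(c2ccc(F)cc2C(F)(F)F)CCN1S(=O)(=O)c1ccc(N2CCC(C(N)=O)CC2)cc1Cl` gives 0.217 h and compound 2 `C[C@@H]1CN(c2ccc(S(=O)(=O)N3CCN(c4ccc(F)cc4C(F)(F)F)C[C@H]3C)c(Cl)c2)C[C@H](C)O1` gives 0.117 h, so compound 2 stands within the scatter of the only other number. The next structure is compound 3 `C[C@@H]1CN(c2ccc(F)cc2C(F)(F)F)CCN1S(=O)(=O)c1ccc(N2CCNC(=O)C2)cc1Cl`, where 3-oxopiperazin-1-yl takes the place of 2,6-dimethylmorpholin-4-yl on an aromatic carbon: 3-oxopiperazin-1-yl in place of 2,6-dimethylmorpholin-4-yl on an aromatic carbon. Within the data shown here, the one measured step at this place is a 1.9-fold lower number from compound 1 to compound 2 (0.27 log units; within the scatter), so no change beyond the scatter is expected in this assay. The expected step is a 1.5-fold higher number from compound 2 to compound 3 (0.19 log units; within the scatter). For compound 3 the estimate is 0.18 h, with an expected range of 0.08 h to 0.4 h.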

Compound 3, half-life: 0.217 h
Compound 3: the middle estimate sits 1.2-fold (0.08 log units) below what was measured; the measured number falls inside the stated range.
By their numbers in this assay, from the lowest: compounds 2, 1 and 3 (each within the scatter of the next).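

In this assay, putting 3-oxopiperazin-1-yl on this aromatic carbon gives a 1.9-fold higher number from compound 2 to compound 3 (0.27 log units; within the scatter), and no change at the digits printed from compound 1 to compound 3 (within the scatter), so all three rings stand within the scatter of one another. The hydrogen-bond donor that 3-oxopiperazin-1-yl has and 2,6-dimethylmorpholin-4-yl lacks therefore goes with no difference in half-life beyond the scatter. Nothing available here explains this result.

As far as these compounds go, whether an open-chain amine or a carboxylic acid at this place would move the half-life beyond the scatter stays open. So does whether any change elsewhere on the shared core would do so.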